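What a Nitro Group Might Do Here

The source may hold more compounds than are shown below. What is called first, only, known or untested is meant among the compounds shown, and "the series" means these compounds.

In a functional assay on T98G cells (Homo sapiens) for inhibition, read by MTT assay, with a stated time of 72 h (a lower number here means a stronger inhibitor, a higher number a weaker inhibitor), compound 3 (`CC1(C)CC(NC(=S)Nc2ccccc2)c2cc(Cl)ccc2O1`) gives 37000 nM, the weakest of the three measured compounds. Compound 1 (`CC1(C)CC(NC(=S)Nc2ccc(C#N)cc2)c2cc(Cl)ccc2O1`) gives 10000 nM. Compound 2 (`CC1(C)CC(NC(=S)Nc2ccc([N+](=O)[O-])cc2)c2cc(Br)ccc2O1`), which carries nitro but has bromine instead of chlorine, gives 5000 nM. Compound 4 (`CC1(C)CC(NC(=S)Nc2ccc([N+](=O)[O-])cc2)c2cc(Cl)ccc2O1`) differs from compound 3 by nitro in place of hydrogen on an aromatic carbon. For the measured compounds named here, the one measured step that bears on this is a 3.7-fold higher number from compound 1 to compound 3 (0.57 log units; beyond the scatter), with hydrogen in place of cyano and a modest size. Read in reverse, it suggests that replacing that hydrogen lowers the number in this assay, and the value of compound 2 at 5000 nM suggests a somewhat larger drop here. The expected step is a 5.3-fold lower number from compound 3 to compound 4 (0.72 log units; beyond the scatter). Compound 4 is estimated at 7000 nM, with an expected range of 3000 nM to 16000 nM.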

Compound 4, half-maximal inhibitory concentration: 4000 nM
Compound 4: the middle estimate sits 1.8-fold (0.24 log units) above what was measured; measured number inside the range.
By their numbers in this assay, from the lowest: compounds 4, 2 and 1 (each within the scatter of the next, the first and the last beyond it); then compound 3.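

In this assay, nitro in place of hydrogen on the aromatic carbon para to a large group gives a 9.3-fold lower number from compound 3 to compound 4 (0.97 log units; beyond the scatter). Nitro in place of cyano at the same carbon gives a 2.5-fold lower number from compound 1 to compound 4 (0.40 log units; beyond the scatter), so the choice between these two groups can be read beyond the scatter. Chloro in place of bromo, with nitro present, gives a 1.3-fold lower number from compound 2 to compound 4 (0.10 log units; within the scatter), which lies within the scatter, and nothing shown explains any of these steps.

From the compounds shown here alone, it remains open how an amine or a carboxylic acid at this carbon would compare with nitro. Also open, going by these compounds, is whether a methoxy group would give a number as low.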